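A few compounds are considered here, and "the series" means these few. Any claim that something is new, unique, unknown or untested is made for them only; others in the source may bear on it.

The study sets out from compound 1, whose structure is `COc1cc(C2=NN(C(C)=O)C(c3cccc(F)c3)O2)cc(OC)c1OC`. In a functional assay on BGC-823 cells (Homo sapiens) for antiproliferative activity, read by MTT assay, tested at 1 uM (a higher number here means a stronger effect of the compound at the concentration tested, a lower number a weaker effect), compound 1 gives 14.7%. Two other compounds were measured alongside it. Compound 2, with the structure `COc1cccc(/C=N/NC(=O)c2cc(OC)c(OC)c(OC)c2)c1OC`, shows in this assay a value of -0.1%, and compound 3, with the structure `COc1cc(C(=O)N/N=C/c2cccc(F)c2)cc(OC)c1OC`, reaches in this assay a value of 13.6%. Compound 1 therefore carries the highest of the three numbers, but its distance to compound 3 lies within the scatter of this kind of measurement, so the two cannot be told apart; only the gap to compound 2 lies beyond the scatter.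

The next compound, compound 4, has the structure `COc1ccc(OC)c(C2OC(c3cc(OC)c(OC)c(OC)c3)=NN2C(C)=O)c1`. It differs from compound 1 in one place, namely (2,5-dimethoxyphenyl in place of 3-fluorophenyl on a saturated ring carbon), while the rest of compound 1 is kept. Going by the values given here, no measured pair in this set shows what such an exchange does, so any expectation rests on compound 1 alone. Compound 4 is estimated to land close to compound 1, with the step of a number 0.3 percentage points higher from compound 1 to compound 4 (within the scatter) expected to stay within the scatter of this assay, in no clear direction. The value of compound 4 in this assay is estimated at 15%, ranging from 0% to 35%.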

Compound 4, a percentage reported as inhibition, at one concentration (the size of the read-out at that concentration, not a potency): 0.4%
Estimate against measurement, compound 4: 14.6 percentage points above; low and high end bracket the measured number.
By their numbers in this assay, from the lowest: compounds 2 and 4 (each within the scatter of the next); then compounds 3 and 1 (each within the scatter of the next).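

Going by these compounds alone, exchanging 3-fluorophenyl for 2,5-dimethoxyphenyl on the saturated ring carbon is the first change in one place that can be read in this set, and in this assay it gives a number 14.3 percentage points lower from compound 1 to compound 4 (beyond the scatter). This shows that the position is not indifferent to the aromatic group it carries: with the rest of compound 1 kept, compound 4 stands at 0.4%, so the inhibition seen at the tested concentration depends on which substituted phenyl sits on this ring carbon. No measurement shown here accounts for the drop, which therefore remains an observation about this one pair.

This single step cannot separate the departure of the fluorine from the arrival of the two methoxy groups, and it cannot show whether one methoxy group alone would give the same result as both together. It also leaves open how an unsubstituted phenyl, a 3-methoxyphenyl, a 3-chlorophenyl or an aminomethyl group would fare on the same ring carbon, and whether a propionyl group in place of the acetyl group would change the picture.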